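A few compounds are considered here, and "the series" means these few. Any claim that something is new, unique, unknown or untested is made for them only; others in the source may bear on it.

In a functional assay on SW-620 cells (Homo sapiens) for cytotoxicity, read by MTT assay, with a stated time of 72 h (on this read-out lower numbers stand for stronger inhibition and higher numbers for weaker inhibition), compound 1 (`COc1ccc(/C=C2\CCC/C(=C\c3cccc(O)c3)C2=O)cc1OC`) gives 1900 nM and compound 2 (`COc1ccc(/C=C2\CCC/C(=C\c3cc(Cl)cc(Cl)c3)C2=O)cc1OC`) gives 2500 nM on the same shared core. Those two numbers lie within the usual scatter of each other, so compound 2 stands level with compound 1 on the data so far. Compound 3 (`COc1cc(/C=C2\CCC/C(=C\c3ccc(OC)c(OC)c3)C2=O)ccc1O`) has not yet been measured. It differs from compound 2 by one swap (4-hydroxy-3-methoxyphenyl in place of 3,5-dichlorophenyl on a double-bonded chain carbon bound to a double-bonded ring carbon), with 4-hydroxy-3-methoxyphenyl in place of 3,5-dichlorophenyl on a double-bonded chain carbon bound to a double-bonded ring carbon. Among the measured compounds shown here, the one measured step at this place (a 1.3-fold higher number from compound 1 to compound 2 (0.12 log units; within the scatter)) stayed inside the scatter, so no change beyond the scatter is expected in this assay here, although a single step is thin evidence. The expected step is small (a 1.4-fold lower number from compound 2 to compound 3 (0.14 log units; within the scatter)) and its direction is uncertain. Compound 3 is estimated at 1800 nM (expected range 600 nM to 5000 nM).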

Compound 3, half-maximal inhibitory concentration: 4500 nM
Compound 3: middle estimate off by 2.5-fold (0.40 log units), on the low side; the measured number falls inside the stated range.
By their numbers in this assay, from the lowest: compounds 1, 2 and 3 (each within the scatter of the next, the first and the last beyond it).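

In this assay this position had so far shown only a step inside the scatter, whereas 4-hydroxy-3-methoxyphenyl in place of 3-hydroxyphenyl gives a 2.4-fold higher number from compound 1 to compound 3 (0.37 log units; beyond the scatter) and so shows a first, modest sensitivity to the group placed here. Against 3,5-dichlorophenyl, the same 4-hydroxy-3-methoxyphenyl gives a 1.8-fold higher number from compound 2 to compound 3 (0.26 log units; within the scatter) and therefore cannot be set apart from it. Nothing available explains why the number shifts between these groups.

All three groups at this place are substituted phenyl rings, so the compounds shown leave open what an amine, a carboxylic acid or a longer alkyl chain would do here. Going by these compounds, whether the modest step would hold up on repeated measurement also remains open.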